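Acyl groups on the ring nitrogen of the shared core

This account rests on a few compounds, and the source may have more. Where it says the series, first, only, none or still open, it means among the compounds named here.

Compound 1 `CC(=O)N1c2ccccc2CCC1C(=O)Nc1cc(C(F)(F)F)cc(C(F)(F)F)c1` — in a functional assay on MDA-MB-231 cells (Homo sapiens) for cytotoxicity, read by sulforhodamine B assay, with a stated time of 72 h (a lower number here means a stronger inhibitor of growth, a higher number a weaker inhibitor of growth), compound 1 reaches only a limit of the assay, > 70000 nM.
Compound 2 `CCCC(=O)N1c2ccccc2CCC1C(=O)Nc1cc(C(F)(F)F)cc(C(F)(F)F)c1` — compound 2 gives 15200 nM.
Compound 3 `O=C(Nc1cc(C(F)(F)F)cc(C(F)(F)F)c1)C1CCc2ccccc2N1` — compound 3 gives 8270 nM.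

Compound 3, with the free ring nitrogen, holds the lowest of the two numbers, and its nearest neighbour is compound 2: a 1.8-fold lower number from compound 2 to compound 3 (0.26 log units; within the scatter). The two ends of the series differ more clearly, as an at least 4.6-fold lower number from compound 1 to compound 2 (0.66 log units; beyond the scatter) and an at least 8.4-fold lower number from compound 1 to compound 3 (0.92 log units; beyond the scatter) show; compound 1 sits at the assay limit, (the limit of > 70000 nM in this assay, at which 1 of the 3 values shown sits).

Compound 4 `O=C(Nc1cc(C(F)(F)F)cc(C(F)(F)F)c1)C1CCc2ccccc2N1C(=O)c1cccc(Cl)c1` returns an acyl group to that nitrogen: (3-chlorophenyl)carbonyl in place of hydrogen on a nitrogen on an aromatic ring in a ring. Within the data shown here, the steps that bear on it are the two changes at the same nitrogen. Removing the acetyl gave an at least modest drop, while the propylcarbonyl of compound 2 sat within the scatter of compound 3. A larger acyl group therefore looks tolerated, and in this assay no step beyond the scatter, or at most a small rise, is expected: a 1.3-fold higher number from compound 3 to compound 4 (0.12 log units; within the scatter). Compound 4 is estimated at 11000 nM, between 3500 nM and 40000 nM.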

Compound 4, concentration for 50% growth inhibition: 1190 nM
The estimate for compound 4 lay 9.2-fold (0.97 log units) above the measured number, and the stated range ends above it.
By their numbers in this assay, from the lowest: compound 4; then compounds 3 and 2 (each within the scatter of the next). At a limit, above all of these: compound 1.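

Among these compounds, at the nitrogen on the aromatic ring, an acyl group can lower the number in this assay rather than merely be tolerated: a 6.9-fold lower number from compound 3 to compound 4 (0.84 log units; beyond the scatter) is the first step beyond the scatter from the free nitrogen to an acylated compound. With the carbonyl kept and only the group on it changed, 3-chlorophenyl in place of propyl gives a 13-fold lower number from compound 2 to compound 4 (1.11 log units; beyond the scatter), so the group on the carbonyl matters at this position. Compound 1 is a limit of the assay, so an at least 58-fold lower number from compound 1 to compound 4 (1.76 log units; beyond the scatter) counts only as a bound: the limit of > 70000 nM in this assay, at which 1 of the 4 values shown sits.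

Going by these compounds, whether the drop follows the aromatic ring or its chlorine remains open, and a plain phenylcarbonyl group would separate the two. Also open, on these data alone, is how a longer alkyl chain, or an amine on the acyl group, would behave at this nitrogen.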